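Swapping Fluoro for Hydrogen on Compound 3

The source may report more compounds than this note shows. Statements on the series, on what has been measured and on what is new or still open speak of the compounds shown alone.

In a functional assay on DU-145 cells (Homo sapiens) for cytotoxicity, read by MTT assay (a higher number here means a weaker inhibitor, a lower number a stronger inhibitor), compound 1 `COc1ccc(CSc2nnc([C@@H](C)c3ccc4cc(OC)ccc4c3)n2-c2ccc(Cl)cc2)cc1` gives 72600 nM, compound 2 `COc1ccc2cc([C@H](C)c3nnc(SCc4ccc(Cl)cc4)n3-c3ccc(Cl)cc3)ccc2c1` gives 109000 nM, and compound 3 `COc1ccc2cc([C@H](C)c3nnc(SCc4ccc(F)cc4)n3-c3ccc(Cl)cc3)ccc2c1` gives 33600 nM, the lowest of the three numbers. Compound 4 `COc1ccc2cc([C@H](C)c3nnc(SCc4ccccc4)n3-c3ccc(Cl)cc3)ccc2c1` differs from compound 3 by one change: hydrogen in place of fluoro on an aromatic carbon. The measured steps swap groups at this same place. They show a 1.5-fold higher number from compound 1 to compound 2 (0.18 log units; within the scatter) for chloro replacing methoxy, a 2.2-fold lower number from compound 1 to compound 3 (0.33 log units; beyond the scatter) for fluoro replacing methoxy, and a 3.2-fold lower number from compound 2 to compound 3 (0.51 log units; beyond the scatter) for fluoro replacing chloro. Within the data shown here, no measured compound carries hydrogen there, so the evidence is indirect, but all these steps are small and fluoro sits lowest. A small rise is therefore expected, namely a 1.5-fold higher number from compound 3 to compound 4 (0.17 log units; within the scatter). Compound 4 is estimated at 50000 nM, with an expected range of 22000 nM to 110000 nM.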

Compound 4, half-maximal inhibitory concentration: 35800 nM
Compound 4: the middle estimate sits 1.4-fold (0.15 log units) above what was measured, and the stated range covers the measured number.
By their numbers in this assay, from the lowest: compounds 3 and 4 (each within the scatter of the next); then compounds 1 and 2 (each within the scatter of the next).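

In this assay the fluoro proves dispensable: a 1.1-fold higher number from compound 3 to compound 4 (0.03 log units; within the scatter) is all that separates the 4-fluorobenzyl from the benzyl. Hydrogen also gives this position a direct baseline, and the two larger groups stand apart from it, with a 3.0-fold lower number from compound 2 to compound 4 (0.48 log units; beyond the scatter) on losing chloro and a 2.0-fold lower number from compound 1 to compound 4 (0.31 log units; beyond the scatter) on losing methoxy. No measured evidence here explains these differences. On these data alone, whether an amine, a carboxylic acid or a longer chain at this place would lower the number further remains open. So does whether the same order of groups would hold in other cell lines.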